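This account rests on a few compounds, and the source may have more. Where it says the series, first, only, none or still open, it means among the compounds named here.

Of the compounds shown here, three sharing one core have been tested in a functional assay on KB cells (Homo sapiens) for cytotoxicity, read by MTT assay, with a stated time of 72 h; a lower number here means a stronger inhibitor, a higher number a weaker inhibitor. Compound 1 `O=C(NC(=S)NNc1ncnc2ccccc12)c1ccc(C(F)(F)F)cc1` gives 7920 nM. Compound 2 `O=C(NC(=S)NNc1ncnc2ccccc12)c1cccc(Cl)c1` gives 4740 nM. Compound 3 `O=C(NC(=S)NNc1ncnc2ccccc12)c1ccc(Cl)cc1` gives 3940 nM. Compound 3 therefore stands close to both of the others: the step of a 2.0-fold lower number from compound 1 to compound 3 (0.30 log units; within the scatter) and the step of a 1.2-fold lower number from compound 2 to compound 3 (0.08 log units; within the scatter) are each within the scatter, so none of the three can be set apart from the rest on the numbers shown.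

Compound 4 `O=C(NC(=S)NNc1ncnc2ccccc12)c1ccccc1F` has not yet been measured. It differs from compound 3 in one place: 2-fluorophenyl in place of 4-chlorophenyl on a carbonyl carbon. For the measured compounds named here, two measured steps bear on this change. The step of a 1.2-fold lower number from compound 2 to compound 3 (0.08 log units; within the scatter) shows that moving the chloro group on the phenyl ring leaves the number essentially unchanged, and the step of a 2.0-fold lower number from compound 1 to compound 3 (0.30 log units; within the scatter) shows that swapping one halogen-type substituent for another also stays within the scatter. On that basis compound 4 is expected to show no step beyond the scatter in this assay, so that a 1.3-fold higher number from compound 3 to compound 4 (0.10 log units; within the scatter) is the estimated change. Compound 4 is accordingly estimated at 5000 nM, with a range from 2000 nM to 15000 nM.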

Compound 4, half-maximal inhibitory concentration: 2510 nM
Estimate against measurement, compound 4: 2.0-fold (0.30 log units) above; the measured number falls inside the stated range.
By their numbers in this assay, from the lowest: compounds 4, 3, 2 and 1 (each within the scatter of the next, the first and the last beyond it).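

In this assay, the change on the carbonyl carbon to 2-fluorophenyl gives a 1.6-fold lower number from compound 3 to compound 4 (0.20 log units; within the scatter) and, set against the other chloro isomer, a 1.9-fold lower number from compound 2 to compound 4 (0.28 log units; within the scatter), so neither step leaves the scatter. For the compounds shown here, the earlier compounds carried only chloro and trifluoromethyl groups, so this is the first sign that this place accepts a different halogen, at a different ring position, with no clear shift in the number. The series also now has a spread that its first three members lacked: compound 4 at 2510 nM and compound 1 at 7920 nM lie beyond the scatter of each other, although every listed step remains within it.

Nothing shown accounts for these numbers, so they describe the spread of values without explaining it. It remains open whether an amine, a carboxylic acid or a longer chain in place of these halogen groups on the phenyl ring would move the number beyond the scatter, and whether the unsubstituted phenyl would differ from the compounds shown.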